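Chain lengthening in a small oral series

This account rests on a few compounds, and the source may have more. Where it says the series, first, only, none or still open, it means among the compounds named here.

Measured so far:
compound 1, `CCc1ccc(-c2cc(Cl)cc(C(=O)Nc3nn[nH]n3)n2)cc1`, 100%
compound 2, `CCCCc1ccc(-c2cc(Cl)cc(C(=O)Nc3nn[nH]n3)n2)cc1`, 83%
compound 3, `Cc1ccc(-c2cc(C)cc(C(=O)Nc3nn[nH]n3)n2)cc1`, 100%

In a functional assay on the whole organism with Rattus norvegicus as the target, at a dose of 3 mg/kg by the oral route (on this read-out lower numbers stand for a weaker effect and higher numbers for a stronger effect at the one dose given), compound 1 gives 100%. Compound 2 gives 83%, and the step is a number 17 percentage points lower from compound 1 to compound 2 (beyond the scatter), brought about by ethyl in place of hydrogen on a saturated chain carbon, two bonds along the chain from an aromatic carbon. Compound 3 gives 100% in this assay; against compound 1 there is no change at the digits printed, within the scatter. The difference between the cores of compound 1 and compound 3 is not broken down here.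

Compound 4, `CCCc1cc(C(=O)Nc2nn[nH]n2)nc(-c2ccc(C)cc2)c1`, is not yet measured. It differs from compound 3 by ethyl in place of hydrogen on a saturated chain carbon bound to an aromatic carbon. This is the same kind of change as from compound 1 to compound 2, but the place is not the same: there the carbon sat two bonds along the chain from an aromatic carbon, here it is bound to an aromatic carbon, and the core carrying it is different.

Among the measured compounds shown here, the one earlier example rests on a single pair, so the expectation is loose. Because a number 17 percentage points lower from compound 1 to compound 2 (beyond the scatter) was modest, compound 4 is expected to show a step of about a number 15 percentage points lower from compound 3 to compound 4 (beyond the scatter). In this assay compound 4 is estimated at 85%, between 65% and 100%.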

Compound 4, a percentage reported as inhibition, in the whole organism at one dose (the size of the read-out at that dose, not a potency): 50%
Beside the measured number, compound 4's estimate is 35 percentage points above it; measured number below the stated range.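

In this assay, ethyl in place of hydrogen on a saturated chain carbon bound to an aromatic carbon gives a large step, a number 50 percentage points lower from compound 3 to compound 4 (beyond the scatter). The change lowers the number in both pairs, but its size does not carry over from one pair to the other: the same change on two cores in this assay, a number 17 percentage points lower (beyond the scatter) from compound 1 to compound 2 and a number 50 percentage points lower (beyond the scatter) from compound 3 to compound 4, 33 percentage points apart, beyond the scatter of two such steps These two pairs differ in the core and also in the place of the change, so they do not show whether the core, the place or both set the size of the step, and two pairs make no general rule for the series.

Still open, from the compounds shown here alone, is how a longer chain such as pentyl, or a chain ending in a carboxylic acid or an amine, would read at this place on the core of compound 3. Also open, going by these compounds, is how the step would compare on the two cores with the change at the same place on each, which would separate the core from the place.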